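This account rests on a few compounds, and the source may have more. Where it says the series, first, only, none or still open, it means among the compounds named here.

Measured compounds:
- compound 1, `CCCn1c(=N)sc2cc(OC(F)(F)F)ccc21`, in a functional assay on the whole organism with Rattus norvegicus as the target (on this read-out lower numbers stand for an effect already at smaller amounts and higher numbers for an effect only at larger amounts of compound), gives 4.5 mg/kg
- compound 2, `CCN(CC)C(=O)Cn1c(=N)sc2cc(OC(F)(F)F)ccc21`, in this assay gives 9 mg/kg
- compound 3, `CNS(=O)(=O)CCn1c(=N)sc2cc(OC(F)(F)F)ccc21`, in this assay gives 4 mg/kg

Compound 3 sits at the low end of the three numbers. Going by the values given here, its separation from compound 1, a 1.1-fold lower number from compound 1 to compound 3 (0.05 log units; within the scatter), is within the scatter, so no order between these two can be read; only the step of a 2.3-fold lower number from compound 2 to compound 3 (0.35 log units; beyond the scatter) is beyond the scatter, and that one is modest.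

Compound 4, `C[S+]([O-])CCn1c(=N)sc2cc(OC(F)(F)F)ccc21`, is not yet measured. It differs from compound 3 by a group of 3 heavy atoms (1 carbon, 1 oxygen, 1 sulfur; no ring) in place of a group of 5 heavy atoms (1 carbon, 1 nitrogen, 2 oxygen, 1 sulfur; no ring), on a saturated chain carbon, two bonds along the chain from an aromatic nitrogen.

Among the compounds with values here, two measured steps bear on this change. The step of a 1.1-fold lower number from compound 1 to compound 3 (0.05 log units; within the scatter) shows that putting methylsulfamoyl in place of methyl on a saturated chain carbon, two bonds along the chain from an aromatic nitrogen, left the number within the scatter. The step of a 2.0-fold higher number from compound 1 to compound 2 (0.30 log units; within the scatter), a different replacement on the chain, also stayed within the scatter. Changes at this chain position have so far moved the read-out little, and the group entering in compound 4 is smaller but sits at the same place. No step beyond the scatter is therefore expected in this assay, in either direction.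

Compound 4 is estimated to give 4.5 mg/kg in this assay, with a range from 2 mg/kg to 10 mg/kg, which means an expected step of a 1.1-fold higher number from compound 3 to compound 4 (0.05 log units; within the scatter).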

Compound 4, dose for half-maximal effect: 1.1 mg/kg
Estimate against measurement, compound 4: 4.1-fold (0.61 log units) above, and the stated range ends above it.
By their numbers in this assay, from the lowest: compound 4; then compounds 3, 1 and 2 (each within the scatter of the next, the first and the last beyond it).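

In this assay, this chain position proves able to move the number beyond the scatter: replacing methylsulfamoyl with the group of 3 heavy atoms, which has 0 hydrogen-bond donors, gives a clear step (a 3.6-fold lower number from compound 3 to compound 4 (0.56 log units; beyond the scatter)), whereas the change from compound 1 to compound 3 stayed within the scatter. Compound 4 also stands apart from the other two compounds (a 4.1-fold lower number from compound 1 to compound 4 (0.61 log units; beyond the scatter); an 8.2-fold lower number from compound 2 to compound 4 (0.91 log units; beyond the scatter)), so it has the lowest number of the series, and size alone does not set the order, since compound 1 carries less on this chain than compound 4 yet has the higher number. Nothing available on these compounds accounts for these steps.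

Going by these compounds, it remains open whether the sulfur group itself matters, which methylsulfonyl, a methoxy group or an amine on the same chain would test, and whether a longer chain between the aromatic nitrogen and the sulfur keeps the low number. On these data alone, all four compounds share one core, so whether the step from compound 3 to compound 4 holds on a different core also remains open.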